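The source may hold more compounds than are shown below. What is called first, only, known or untested is meant among the compounds shown, and "the series" means these compounds.

Compound 3 `O=C1N=C(N2CCC[C@H]2C(=O)Nc2ccc3ncnc(Nc4cccc(Cl)c4)c3c2)S/C1=C/c1ccccc1Br` gives the highest number among the measured values in a functional assay on HepG2 cells (Homo sapiens) for antiproliferative activity, read by MTT assay (on this read-out lower numbers stand for stronger inhibition and higher numbers for weaker inhibition), with 24300 nM. Compound 2 `O=C1N=C(N2CCC[C@H]2C(=O)Nc2ccc3ncnc(Nc4cccc(Cl)c4)c3c2)S/C1=C/c1cccs1` gives 4120 nM in this assay. For compound 1 `O=C1N=C(N2CCC[C@H]2C(=O)Nc2ccc3ncnc(Nc4cccc(Cl)c4)c3c2)S/C1=C/c1ccc(Br)s1` this assay reports only a limit, > 50000 nM, and not a number. Compound 4 `O=C1N=C(N2CCC[C@H]2C(=O)Nc2ccc3ncnc(Nc4cccc(Cl)c4)c3c2)S/C1=C/c1cccc(Br)c1` differs from compound 3 by 3-bromophenyl in place of 2-bromophenyl on a double-bonded chain carbon bound to a double-bonded ring carbon. Among the measured compounds shown here, no measured step moves a bromo from one place to another; the steps that touch the same position are a 5.9-fold higher number from compound 2 to compound 3 (0.77 log units; beyond the scatter) and an at least 2.0-fold lower number from compound 1 to compound 3 (0.31 log units; beyond the scatter), while an at least 12-fold lower number from compound 1 to compound 2 (1.08 log units; beyond the scatter) shows that the presence of bromo matters a great deal. A step of a 1.2-fold lower number from compound 3 to compound 4 (0.08 log units; within the scatter) is therefore expected, small and uncertain in direction. Compound 4 is estimated at 20000 nM, with a range from 6000 nM to 60000 nM.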

Compound 4, half-maximal inhibitory concentration: 21300 nM
Beside the measured number, compound 4's estimate is 1.1-fold (0.03 log units) below it; the range from low to high includes it.
By their numbers in this assay, from the lowest: compound 2; then compounds 4 and 3 (each within the scatter of the next). At a limit, above all of these: compound 1.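

Exchanging 2-bromophenyl for 3-bromophenyl on the double-bonded chain carbon makes no change beyond the scatter, with a 1.1-fold lower number from compound 3 to compound 4 (0.06 log units; within the scatter). The 3-bromophenyl group stays clearly apart from thiophen-2-yl, with a 5.2-fold higher number from compound 2 to compound 4 (0.71 log units; beyond the scatter), so among these compounds the place of the bromo on the phenyl ring does not close that gap. The remaining step, an at least 2.3-fold lower number from compound 1 to compound 4 (0.37 log units; beyond the scatter), starts from a value that is a limit and not a number: the limit of > 50000 nM in this assay, at which 1 of the 4 values shown sits.

On these data alone, it remains open how plain phenyl, without bromo, would compare with thiophen-2-yl. Also open, as far as these compounds go, is whether a methoxy or an amine on the phenyl ring would give a different result.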